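Sulfamoylphenyl Replaces Fluorophenyl in an Inactive Spiro Series

The compounds below may be only part of what the source reports. "The series", "measured", "known", "first", "only" and "open" are said of these compounds alone.

Compound 1 `N#CC1=C(N)Oc2c(c3nc4ccccc4nc3c3ccccc23)C12C(=O)N(Cc1cnnn1-c1ccc(F)cc1)c1ccccc12` was examined in a functional assay on HCT-116 cells (Homo sapiens) for antiproliferative activity, read by MTT assay, with a stated time of 48 h (a higher number here means a weaker inhibitor, a lower number a stronger inhibitor), where compound 1 gives only a limit of the assay and no number, > 50000 nM. Compound 2 `CCOc1ccc(-n2nncc2CN2C(=O)C3(C(C#N)=C(N)Oc4c3c3nc5ccccc5nc3c3ccccc43)c3ccccc32)cc1`, with ethoxy in place of fluoro on an aromatic carbon, likewise returns only a limit in this assay, > 50000 nM. For the measured compounds named here, compound 3 `N#CC1=C(N)Oc2c(c3nc4ccccc4nc3c3ccccc23)C12C(=O)N(Cc1cnnn1-c1ccc(N)cc1)c1ccccc12`, with amino in place of fluoro on an aromatic carbon, is the sole member with a number in this assay, 45200 nM. Compound 1 thus stands at a limit rather than at a value, and one further value shown is a limit as well; the common point is the limit of > 50000 nM in this assay, at which 2 of the 3 values shown sit. Compound 4 `N#CC1=C(N)Oc2c(c3nc4ccccc4nc3c3ccccc23)C12C(=O)N(Cc1cnnn1-c1cccc(S(N)(=O)=O)c1)c1ccccc12` differs from compound 1 as follows: 3-sulfamoylphenyl in place of 4-fluorophenyl on an aromatic nitrogen. Two measured steps on the same ring bear on this change: a step that the two limits leave unreadable from compound 1 to compound 2 and an at least 1.1-fold lower number from compound 1 to compound 3 (0.04 log units; that floor lies within the scatter). Neither shows movement beyond the scatter, so no step beyond the scatter is expected in this assay. Compound 4 is therefore estimated at about 50000 nM, expected to fall between 20000 nM and 100000 nM. The expected step is a number no higher from compound 1 to compound 4 (the limit leaves the size open), within the scatter.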

Compound 4, half-maximal inhibitory concentration: 11300 nM
The estimate for compound 4 lay 4.4-fold (0.65 log units) above the measured number; measured number outside the range, below it.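

In this assay, the aryl group on the aromatic nitrogen can move the number beyond the scatter, which the fluoro, ethoxy and amino groups did not show. The 3-sulfamoylphenyl group gives an at least 4.4-fold lower number from compound 1 to compound 4 (0.64 log units; beyond the scatter) and an at least 4.4-fold lower number from compound 2 to compound 4 (0.64 log units; beyond the scatter). It also gives a 4.0-fold lower number from compound 3 to compound 4 (0.60 log units; beyond the scatter), a step between two actual numbers, so the change does not rest on comparisons with limits alone, though compound 1 and compound 2 remain limits of the assay: the limit of > 50000 nM in this assay, at which 2 of the 4 values shown sit.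

Since 3-sulfamoylphenyl differs from 4-fluorophenyl in both the group and the position in its name, the compounds shown do not separate the two. On these data alone, it remains open whether 4-sulfamoylphenyl, or a carboxylic acid or methylsulfonyl group on the same ring, would give a similar step.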